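Swapping a sulfonyl aryl for a carbamate piperidine

A few compounds are considered here, and "the series" means these few. Any claim that something is new, unique, unknown or untested is made for them only; others in the source may bear on it.

Compound 1 `Cn1cncc1CN1CC(N(CC2CCN(C(=O)NC(C)(C)C)CC2)S(=O)(=O)c2ccccn2)Cc2cc(C#N)ccc21` gives 0.6 10^-6 cm/s in an ADME assay on Caco-2 cells (Homo sapiens) for permeability, in the apical to basolateral direction; on this read-out higher numbers stand for higher permeability and lower numbers for lower permeability.
Compound 2 `Cn1cncc1CN1CC(N(CC2CCN(C(=O)C(C)(C)C)CC2)S(=O)(=O)c2ccccn2)Cc2cc(C#N)ccc21` gives 0.5 10^-6 cm/s.
Compound 3 `Cn1cncc1CN1CC(N(Cc2ccc(S(C)(=O)=O)cc2)S(=O)(=O)c2ccccn2)Cc2cc(C#N)ccc21` gives 0.2 10^-6 cm/s.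

Compound 3 stands lowest of the three numbers, with compound 2 nearest and compound 1 furthest, both separated from it by more than the scatter. Compound 4 `CCOC(=O)N1CCC(CN(C2Cc3cc(C#N)ccc3N(Cc3cncn3C)C2)S(=O)(=O)c2ccccn2)CC1` differs from compound 3 by 1-(ethoxycarbonyl)piperidin-4-yl in place of 4-(methylsulfonyl)phenyl on a saturated chain carbon bound to a sulfonamide nitrogen. The step that bears on this change is a 2.5-fold lower number from compound 2 to compound 3 (0.40 log units; beyond the scatter), a modest loss on replacing a piperidinyl group with the aryl group; compound 4 reverses that direction with a related piperidinyl group. The step of a 1.2-fold lower number from compound 1 to compound 2 (0.08 log units; within the scatter) shows that compound 1 and compound 2 sit within the scatter of each other. For compound 4 a step of about a 2.5-fold higher number from compound 3 to compound 4 (0.40 log units; beyond the scatter) in this assay is therefore expected. Compound 4 is estimated at 0.5 10^-6 cm/s, with a range from 0.25 10^-6 cm/s to 1 10^-6 cm/s.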

Compound 4, apparent permeability: 2.6 10^-6 cm/s
Estimate against measurement, compound 4: 5.2-fold (0.72 log units) below; measured number above the stated range.
By their numbers in this assay, from the lowest: compound 3; then compounds 2 and 1 (each within the scatter of the next); then compound 4.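

In this assay, the change on the saturated chain carbon bound to a sulfonamide nitrogen gives a 13-fold higher number from compound 3 to compound 4 (1.11 log units; beyond the scatter), which is larger than the earlier loss on moving to the aryl group. The carbonyl carbon of the piperidine also proves sensitive, although the earlier pair lay within the scatter: ethoxy gives a 5.2-fold higher number from compound 2 to compound 4 (0.72 log units; beyond the scatter) and a 4.3-fold higher number from compound 1 to compound 4 (0.64 log units; beyond the scatter). Nothing available explains why ethoxy stands apart from tert-butyl and (tert-butyl)amino.

The compounds shown leave open whether methoxy or a longer alkoxy chain on that carbonyl carbon would give a similar number.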